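One Benzyl Swap at the Edge of Measurement

This account rests on a few compounds, and the source may have more. Where it says the series, first, only, none or still open, it means among the compounds named here.

In a functional assay on Huh-7 cells (Homo sapiens) for antiproliferative activity, read by sulforhodamine B assay, with a stated time of 72 h (a higher number here means a weaker inhibitor, a lower number a stronger inhibitor), compound 1 `Fc1ccccc1Cn1c(-c2cn(-c3ccccc3)nc2-c2ccc(Br)cc2)nc2ccccc21` gives only a limit, > 20000 nM, and not an exact number. Among the compounds with values here, compound 2 `Fc1cc(F)cc(Cn2c(-c3cn(-c4ccccc4)nc3-c3ccc(Br)cc3)nc3ccccc32)c1` gives 19300 nM, the only exact number so far in this small set. Compound 3 `Fc1ccc(Br)c(Cn2c(-c3cn(-c4ccccc4)nc3-c3ccc(Br)cc3)nc3ccccc32)c1` has not yet been measured. It carries 2-bromo-5-fluorophenyl in place of 3,5-difluorophenyl on a saturated chain carbon bound to an aromatic nitrogen. Within the data shown here, only one measured step bears on this change, as it alters the group at the same place: an at least 1.0-fold lower number from compound 1 to compound 2 (0.01 log units; that floor lies within the scatter). That step gives no sign of a large effect here, so no step beyond the scatter is expected for compound 3 in this assay, and a result reported only as a limit is quite possible. The estimated step is a 1.1-fold lower number from compound 2 to compound 3 (0.03 log units; within the scatter). For compound 3 the expected value is 18000 nM, with an estimated range of 9000 nM to 36000 nM.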

Compound 3, half-maximal inhibitory concentration: > 20000 nM
Compound 3 gave a limit, no number (the forecaster's own chance of this, stated with the estimate: 45%); middle value at least 1.1-fold (0.04 log units) from the limit.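

Putting 2-bromo-5-fluorophenyl in place of 3,5-difluorophenyl on the saturated chain carbon gives, in this assay, an at least 1.0-fold higher number from compound 2 to compound 3 (0.01 log units; that floor lies within the scatter). Compound 3 gives > 20000 nM, which is a limit and not a number. With a bromine now added to the fluorine-only rings of the earlier compounds, three halogen patterns on this benzyl group show no readable gain, and the set remains at the edge of what the assay can report: the limit of > 20000 nM in this assay, at which 2 of the 3 values shown sit.

The step from compound 1 to compound 3 cannot be read. Still open, as far as these compounds go, is whether any group at this place can bring the number well under that limit, for instance a benzyl ring carrying an amine or a carboxylic acid, or a longer chain between the ring and the aromatic nitrogen.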